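This account rests on a few compounds, and the source may have more. Where it says the series, first, only, none or still open, it means among the compounds named here.

Measured compounds:
compound 1 `O=C1[C@@H](NS(=O)(=O)c2cc3c(Cl)nccc3s2)CCN1CCNc1ccncc1` gives 39% in an assay on isolated protein for inhibition of coagulation factor X (Oryctolagus cuniculus), tested at 1 uM; a lower number here means less inhibition, a higher number more inhibition at the concentration tested (going by the name of the read-out);
compound 2 `CC(C)(C)c1ccc(S(=O)(=O)N[C@H]2CCN(CCNc3ccncc3)C2=O)cc1` gives 14% in this assay;
compound 3 `O=C1[C@@H](NS(=O)(=O)c2cc3ccc(Cl)nc3s2)CCN1Cc1cc2[nH]cccc-2n1` gives 23% in this assay.

Compound 2 sits at the bottom of these three numbers. Compound 3 lies within the usual scatter of it, so the two cannot be ordered against each other, while compound 1 lies beyond the scatter and clearly shows more inhibition than compound 2. Among the measured compounds shown here, none of the three pairs differs in only one place, so no single-point step between measured compounds is available.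

The unmeasured compound 4 `CC(C)(C)c1ccc(S(=O)(=O)N[C@H]2CCN(Cc3cc4cc[nH]cc-4n3)C2=O)cc1` is reached from compound 2 by a change at the group carried on a saturated chain carbon bound to the amide-type nitrogen in the ring: a group of 9 heavy atoms (7 carbon, 2 nitrogen; one five-membered aromatic ring with 1 hetero atom, one six-membered aromatic ring with 1 hetero atom) in place of a group of 8 heavy atoms (6 carbon, 2 nitrogen; one six-membered aromatic ring with 1 hetero atom), on a saturated chain carbon bound to an amide-type nitrogen in a ring

For the measured compounds named here, the measured set contains no compound pair that isolates this exchange, so the expectation for compound 4 rests only on the numbers as they stand. Compound 3, which carries a related group with a five-membered aromatic ring and a six-membered aromatic ring, gives 23%, within the scatter of compound 2. The step from compound 2 to compound 4 in this assay is therefore expected to be small, a number 2 percentage points higher from compound 2 to compound 4 (within the scatter), with no direction beyond the scatter. Compound 4 is estimated at 16%, in a range from 4% to 32%.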

Compound 4, a percentage reported as inhibition, at one concentration (the size of the read-out at that concentration, not a potency): 57%
For compound 4 the middle estimate is 41 percentage points below the measured one, outside the stated range (above it).
By their numbers in this assay, from the lowest: compounds 2 and 3 (each within the scatter of the next); then compound 1; then compound 4.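

In this assay, among the compounds shown here, this exchange gives the first step between measured compounds that differ in one place, and the step is large: a number 43 percentage points higher from compound 2 to compound 4 (beyond the scatter). It shows that, on the core of compound 2, the group on a saturated chain carbon bound to an amide-type nitrogen in a ring is not a neutral place, as replacing the ((pyridin-4-yl)amino)methyl group of 8 heavy atoms with a group of 9 heavy atoms, carrying one five-membered and one six-membered aromatic ring, moves the read-out well beyond the scatter. Nothing measured here bears on what lies behind this step.

The compounds shown leave open whether the same exchange gives a step of this size on any core other than that of compound 2, as this single pair is the only one that isolates it. They also leave open which part of the entering group carries the step, and how a simple benzyl group or a pyridin-4-ylmethyl group on a saturated chain carbon bound to an amide-type nitrogen in a ring would compare with compound 4.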